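The source may report more compounds than this note shows. Statements on the series, on what has been measured and on what is new or still open speak of the compounds shown alone.

Working notes on the series.

Compound 1 `Oc1cccc(-c2cc(-c3cccs3)cc(-c3cccc(O)c3)n2)c1` and compound 2 `Oc1ccc(-c2cc(-c3cccs3)cc(-c3cccc(O)c3)n2)cc1` share one core. In a functional assay on HCT-15 cells (Homo sapiens) for cytotoxicity, read by CCK-8 assay (a higher number here means a weaker inhibitor, a lower number a stronger inhibitor), compound 1 gives 3480 nM, and compound 2 gives 1770 nM. The change between them is 4-hydroxyphenyl in place of 3-hydroxyphenyl on an aromatic carbon, and the step is a 2.0-fold lower number from compound 1 to compound 2 (0.29 log units; within the scatter).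

Compound 3 `Oc1cccc(-c2cc(-c3ccccn3)cc(-c3ccccc3O)n2)c1` sits on a second core; the difference between the two cores is not broken down here. In this assay compound 3 gives only a limit, > 50000 nM. This is the limit named in the limit of > 50000 nM in this assay, at which 1 of the 3 values shown sits.

Compound 4 `Oc1ccc(-c2cc(-c3ccccn3)cc(-c3ccccc3O)n2)cc1` is not yet measured. It differs from compound 3 by 4-hydroxyphenyl in place of 3-hydroxyphenyl on an aromatic carbon. Around the place the surroundings are not the same as in the first pair: there the position was meta to a 3-hydroxyphenyl group and meta to a thiophen-2-yl group, here it is meta to a 2-hydroxyphenyl group and meta to a pyridin-2-yl group, so this is the same kind of change rather than the same change.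

The first pair shows a step within the scatter, so a step that the limit leaves unreadable from compound 3 to compound 4 is expected here, resting on compound 1 and compound 2 with a 2.0-fold lower number from compound 1 to compound 2 (0.29 log units; within the scatter). Since compound 3 stands at a limit, compound 4 is expected to give about 60000 nM in this assay, most likely again reported only as a limit.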

Compound 4, half-maximal inhibitory concentration: > 50000 nM
Compound 4 ended at the assay's limit (the forecaster's own chance of this, stated with the estimate: 70%); the middle value does not contradict the limit.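

In this assay compound 4 gives > 50000 nM, a limit of the assay and not a number, and compound 3 stands at the same limit, so no step can be read between compound 3 and compound 4. The compounds shown leave open whether 4-hydroxyphenyl in place of 3-hydroxyphenyl changes the potency on the core of compound 3 at all.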